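Extending the Amide Chain of Compound 2 by One Carbon

The source may report more compounds than this note shows. Statements on the series, on what has been measured and on what is new or still open speak of the compounds shown alone.

Of the compounds shown here, three sharing one core have been tested in an assay on microsomes from Testis (strain Sprague-Dawley) for inhibition of steroid 17-alpha-hydroxylase/17,20 lyase (Rattus norvegicus); a higher number here means a weaker inhibitor, a lower number a stronger inhibitor. Compound 1 `COc1ccc2cc([C@](O)(c3c[nH]cn3)C(C)C)ccc2c1` gives 21 nM in this assay. Compound 2 `CCNC(=O)c1ccc2cc(C(O)(c3c[nH]cn3)C(C)C)ccc2c1` gives 11 nM, the lowest number of the three, though its difference from compound 1 lies within the scatter, so the two cannot be ordered. Compound 3 `CNC(=O)c1ccc2cc(C(O)(c3c[nH]cn3)C(C)C)ccc2c1C` gives 200 nM, a number clearly higher than that of compound 2 and beyond the scatter.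

Compound 4 `CCCNC(=O)c1ccc2cc(C(O)(c3c[nH]cn3)C(C)C)ccc2c1` has not yet been measured. It differs from compound 2 in one place: methyl in place of hydrogen on a saturated chain carbon, two bonds along the chain from an amide-type nitrogen. Among the measured compounds shown here, no step between measured compounds describes this kind of change, so the expectation rests on the change itself. Adding a single carbon to a saturated chain on the amide is a small alteration, and compound 2 is expected to keep most of its potency, with a step from compound 2 to compound 4 of a 1.2-fold higher number from compound 2 to compound 4 (0.07 log units; within the scatter), expected to lie within the scatter or only slightly beyond it.

For compound 4, an inhibitory concentration of 13 nM is estimated, with a range from 5 nM to 35 nM.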

Compound 4, half-maximal inhibitory concentration: 13 nM
For compound 4 middle estimate and measured number coincide at the digits printed; the range from low to high includes it.
By their numbers in this assay, from the lowest: compounds 2, 4 and 1 (each within the scatter of the next); then compound 3.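

Among the compounds shown here, compound 2 and compound 4 form the first pair here that differs in only one place, so the effect of a single change can be read directly. In this assay, replacing ethylamino with propylamino gives a 1.2-fold higher number from compound 2 to compound 4 (0.07 log units; within the scatter), so the two compounds cannot be ordered, and this saturated chain accepts methyl in place of hydrogen, two bonds along from the amide-type nitrogen, without a measurable loss of potency. No supporting measurement speaks to what lies behind this match.

From the compounds shown here alone, a single added carbon gives only one point, so how far the chain can grow before the number rises remains unknown. A butyl chain, a branched isopropyl group, or a chain ending in an amine or a carboxylic acid could each behave differently at this position.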